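Swapping Fluoro for Hydrogen on Compound 3

A few compounds are considered here, and "the series" means these few. Any claim that something is new, unique, unknown or untested is made for them only; others in the source may bear on it.

In a functional assay on HepG2 cells (Homo sapiens) for antiproliferative activity, read by MTT assay, with a stated time of 72 h (on this read-out lower numbers stand for stronger inhibition and higher numbers for weaker inhibition), compound 1 (`CN(C)CCn1cccc1/C=N/NC(=O)Nc1ccc(Oc2ccnc3[nH]ccc23)c(F)c1`) gives 8980 nM and compound 2 (`CCN(CC)CCn1cccc1/C=N/NC(=O)Nc1ccc(Oc2ccnc3[nH]ccc23)cc1`) gives 5880 nM while compound 3 (`CN1CCN(CCCn2cccc2/C=N/NC(=O)Nc2ccc(Oc3ccnc4[nH]ccc34)c(F)c2)CC1`) gives 2740 nM as the lowest number of the three. Lower numbers mean stronger inhibition here, so compound 3 leads this small set, though none of the three reaches a low value on this scale.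

The next compound is compound 4 (`CN1CCN(CCCn2cccc2/C=N/NC(=O)Nc2ccc(Oc3ccnc4[nH]ccc34)cc2)CC1`), which matches compound 3 except for hydrogen in place of fluoro on an aromatic carbon. For the measured compounds named here, no measured step isolates this change. Going by the values given here, the one measured step between compounds that differ in a single place (a 3.3-fold lower number from compound 1 to compound 3 (0.52 log units; beyond the scatter)) swaps dimethylamino for (4-methylpiperazin-1-yl)methyl on the side chain, so it speaks to the chain and not to the fluoro group. Compound 1 and compound 2 differ in more than one place, so the gap between their values cannot be assigned to fluoro alone.

With no evidence for a clear shift, the expected step in this assay is small (a 1.1-fold lower number from compound 3 to compound 4 (0.02 log units; within the scatter)) and none beyond the usual scatter is foreseen. The estimated value for compound 4 is 2600 nM (expected range 1100 nM to 5800 nM).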

Compound 4, half-maximal inhibitory concentration: 2760 nM
For compound 4 the middle estimate is 1.1-fold (0.03 log units) below the measured one; low and high end bracket the measured number.
By their numbers in this assay, from the lowest: compounds 3 and 4 (each within the scatter of the next); then compounds 2 and 1 (each within the scatter of the next).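

In this assay, putting hydrogen in place of fluoro on this aromatic carbon, which is ortho to a large group and meta to a large group, gives a 1.0-fold higher number from compound 3 to compound 4 (0.00 log units; within the scatter), so this read-out does not separate the two atoms at this position, at least with this side chain. Compound 4 also gives a single-change view of the side chain without the fluoro group: (4-methylpiperazin-1-yl)methyl in place of diethylamino gives a 2.1-fold lower number from compound 2 to compound 4 (0.33 log units; beyond the scatter), a modest step in the same direction as a 3.3-fold lower number from compound 1 to compound 3 (0.52 log units; beyond the scatter), where the same group replaces dimethylamino on a fluoro-bearing compound. Nothing measured here explains why the fluoro group leaves the number unchanged while the side-chain swaps move it.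

The compounds shown compare only hydrogen and fluoro on this carbon, so they leave open whether chloro, methoxy or trifluoromethyl there would also leave the number unmoved. They also leave open whether a morpholine or a longer chain in place of the present side chain would carry the number further down, since all four values remain in the micromolar range.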